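Notes on the series: carbamoyl replacing isopropoxy

A few compounds are considered here, and "the series" means these few. Any claim that something is new, unique, unknown or untested is made for them only; others in the source may bear on it.

Measured compounds:
compound 1, `CCOc1cc(=O)oc2cc(OCc3cccc(Cl)c3)ccc12`, 115 nM
compound 2, `CC(C)Oc1cc(=O)oc2cc(OCc3cccc(Cl)c3)ccc12`, 24500 nM
compound 3, `CCNc1cc(=O)oc2cc(OCc3cccc(Cl)c3)ccc12`, 28.2 nM

Read-out throughout is an assay on isolated protein (strain Sprague-Dawley) for inhibition of Amine oxidase [flavin-containing] B (Rattus norvegicus), read by spectrophotometry, with a stated time of 5 min; on this read-out lower numbers stand for stronger inhibition and higher numbers for weaker inhibition. Compound 2 gives the highest number of the three, with a 210-fold higher number from compound 1 to compound 2 (2.33 log units; beyond the scatter) as its nearest neighbour and an 870-fold lower number from compound 2 to compound 3 (2.94 log units; beyond the scatter) as the furthest. Compound 4, `NC(=O)c1cc(=O)oc2cc(OCc3cccc(Cl)c3)ccc12`, is not yet measured; it differs from compound 2 in one place: carbamoyl in place of isopropoxy on an aromatic carbon.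

Among the measured compounds shown here, two measured steps bear on this change. The first, a 210-fold higher number from compound 1 to compound 2 (2.33 log units; beyond the scatter), shows that adding a methyl on the saturated chain carbon at this position raised the number strongly. The second, an 870-fold lower number from compound 2 to compound 3 (2.94 log units; beyond the scatter), shows that replacing isopropoxy by a group of the ethylamino kind lowered it strongly. Both steps start from or end at compound 2. Carbamoyl, like ethylamino, is a group with one hydrogen-bond donor and fewer heavy atoms than isopropoxy, so for compound 4 a large downward step, an 82-fold lower number from compound 2 to compound 4 (1.91 log units; beyond the scatter), is expected. For the measured compounds named here, whether compound 4 reaches the region of compound 1 or compound 3 cannot be told from the data; no carbamoyl analogue has been measured. Compound 4 is therefore estimated at 300 nM, within a range from 30 nM to 3000 nM.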

Compound 4, half-maximal inhibitory concentration: 234 nM
Compound 4: the middle estimate sits 1.3-fold (0.11 log units) above what was measured, within the range that was stated.
By their numbers in this assay, from the lowest: compound 3; then compound 1; then compound 4; then compound 2.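

In this assay, the step of a 100-fold lower number from compound 2 to compound 4 (2.02 log units; beyond the scatter) shows that a group attached through a carbon, with its carbonyl on the aromatic carbon opposite the ring oxygen, also lies far below compound 2, so the high number of compound 2 does not depend on the other groups being linked through oxygen or nitrogen. Carbamoyl does not match ethylamino, as an 8.3-fold higher number from compound 3 to compound 4 (0.92 log units; beyond the scatter) shows, and it also sits modestly on the weaker side of ethoxy, as a 2.0-fold higher number from compound 1 to compound 4 (0.31 log units; beyond the scatter) shows, so its hydrogen-bond donor brings no gain over the ethoxy of compound 1. No measurement at hand explains this order among the three groups.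

The compounds shown leave open whether the high number of compound 2 belongs to branching as such, which isopropylamino or a branched amide such as isopropylcarbamoyl would test on the same core. They also leave open how far the carbon-linked side of this position extends, for instance to a carboxylic acid, its methyl ester or methylcarbamoyl.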